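Hydrazone aryl swap in the triazole-pyridine ether series

The source may report more compounds than this note shows. Statements on the series, on what has been measured and on what is new or still open speak of the compounds shown alone.

Measured compounds:
- compound 1 `CN(C)CCn1cnnc1-c1cc(Oc2ccc(NC(=O)N/N=C/c3ccc(Cl)cc3Cl)cc2F)ccn1` gives 130 nM in a functional assay on NCI-H460 cells (Homo sapiens) for cytotoxicity, read by MTT assay, with a stated time of 72 h; a higher number here means a weaker inhibitor, a lower number a stronger inhibitor
- compound 2 `COc1ccc(OC)c(/C=N/NC(=O)Nc2ccc(Oc3ccnc(-c4nncn4CCN(C)C)c3)c(F)c2)c1` gives 2930 nM in this assay
- compound 3 `CN(C)CCn1cnnc1-c1cc(Oc2ccc(NC(=O)N/N=C/c3ccc(O)c(Br)c3)cc2F)ccn1` gives 430 nM in this assay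

Compound 3 stands second highest of the three numbers: the step of a 3.3-fold higher number from compound 1 to compound 3 (0.52 log units; beyond the scatter) separates it from compound 1, and the step of a 6.8-fold lower number from compound 2 to compound 3 (0.83 log units; beyond the scatter) from compound 2, both beyond the scatter.

Compound 4 `COc1ccc(/C=N/NC(=O)Nc2ccc(Oc3ccnc(-c4nncn4CCN(C)C)c3)c(F)c2)c(OC)c1OC` is not yet measured. It differs from compound 3 in one place: 2,3,4-trimethoxyphenyl in place of 3-bromo-4-hydroxyphenyl on a carbon with a double bond to nitrogen.

For the measured compounds named here, two measured steps bear on this change, since both replace a halogenated aryl on the same carbon with a methoxy-bearing aryl. The step of a 23-fold higher number from compound 1 to compound 2 (1.35 log units; beyond the scatter) was large, and the reverse reading of the pair, a 6.8-fold lower number from compound 2 to compound 3 (0.83 log units; beyond the scatter), was modest. A trimethoxyphenyl has not been measured here, so the size of its effect rests only on the dimethoxy case of compound 2. Because of a 23-fold higher number from compound 1 to compound 2 (1.35 log units; beyond the scatter) and a 6.8-fold lower number from compound 2 to compound 3 (0.83 log units; beyond the scatter), a step upward beyond the scatter is expected in this assay for compound 4.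

The estimate for compound 4 is 3000 nM with a range of 800 nM to 12000 nM in this assay, which is expected to correspond to a step of a 7.0-fold higher number from compound 3 to compound 4 (0.84 log units; beyond the scatter).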

Compound 4, half-maximal inhibitory concentration: 1790 nM
Estimate against measurement, compound 4: 1.7-fold (0.22 log units) above, and the stated range covers the measured number.
By their numbers in this assay, from the lowest: compound 1; then compound 3; then compounds 4 and 2 (each within the scatter of the next).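

In this assay, 2,3,4-trimethoxyphenyl joins 2,5-dimethoxyphenyl on the high side of the series, with a 4.2-fold higher number from compound 3 to compound 4 (0.62 log units; beyond the scatter) and a 14-fold higher number from compound 1 to compound 4 (1.14 log units; beyond the scatter), so among these four compounds both methoxy-bearing aryl groups give higher numbers than both halogen-bearing ones, and no compound goes against this split. Within the methoxy-bearing pair, a 1.6-fold lower number from compound 2 to compound 4 (0.21 log units; within the scatter), so at this position the 2,3,4-trimethoxyphenyl and 2,5-dimethoxyphenyl groups cannot be told apart in this read-out, despite their different substitution. The measurements shown give no account of why the aryl groups on this carbon separate in this way.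

The four compounds do not separate the presence of methoxy groups from the absence of halogen, as every aryl group here carries one or the other, and an unsubstituted phenyl or a phenyl bearing a single methoxy group would bear directly on that question. Also open, from the compounds shown here alone, is how this position responds to an aryl group carrying an amine or a carboxylic acid, and whether the split seen in this assay extends beyond these four aryl groups.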